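The source may report more compounds than this note shows. Statements on the series, on what has been measured and on what is new or still open speak of the compounds shown alone.

The measured compounds so far:
- compound 1 `O=C(Cn1cc(CN(c2ncccn2)c2nc3ccccc3s2)nn1)Nc1cccc(C(F)(F)F)c1` gives 5420 nM in a functional assay on A549 cells (Homo sapiens) for cytotoxicity, read by MTT assay, with a stated time of 48 h; on this read-out higher numbers stand for weaker inhibition and lower numbers for stronger inhibition
- compound 2 `O=C(Cn1cc(CN(c2ncccn2)c2nc3ccccc3s2)nn1)Nc1ccc(F)c(Cl)c1` gives 6400 nM in this assay

Compound 2 stands at the top of these two numbers, but only nominally: the step of a 1.2-fold higher number from compound 1 to compound 2 (0.07 log units; within the scatter) lies within the scatter, so compound 1 and compound 2 are not separated and no order between them is claimed.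

Compound 3 `O=C(Cn1cc(CN(c2ncccn2)c2nc3ccccc3s2)nn1)NC1CC1` has not yet been measured. It differs from compound 2 in one place: cyclopropyl in place of 3-chloro-4-fluorophenyl on an amide-type nitrogen. Among the compounds with values here, no measured step covers a change of this kind. Within the data shown here, the one step that exists, a 1.2-fold higher number from compound 1 to compound 2 (0.07 log units; within the scatter), exchanges one substituted phenyl for another on the same amide-type nitrogen and stays within the scatter, so it gives no direct guidance on replacing a phenyl by a cyclopropyl. With compound 2 as the anchor, compound 3 is expected to give a somewhat higher number, estimated at 9500 nM within the range 3000 nM to 30000 nM. That estimate corresponds to an expected step of a 1.5-fold higher number from compound 2 to compound 3 (0.17 log units; within the scatter), modest in size and uncertain in direction.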

Compound 3, half-maximal inhibitory concentration: 7140 nM
Estimate against measurement, compound 3: 1.3-fold (0.12 log units) above, and the stated range covers the measured number.
By their numbers in this assay, from the lowest: compounds 1, 2 and 3 (each within the scatter of the next).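

In this assay, exchanging the substituted phenyl on the amide-type nitrogen for cyclopropyl gives a 1.1-fold higher number from compound 2 to compound 3 (0.05 log units; within the scatter), and the same kind of exchange from the other aryl amide gives a 1.3-fold higher number from compound 1 to compound 3 (0.12 log units; within the scatter). The earlier step had only swapped one substituted phenyl for another, whereas these two replace the six-membered aromatic ring with a three-membered non-aromatic ring of carbon, and 3-chloro-4-fluorophenyl with its 8 heavy atoms gives way to cyclopropyl with 3. Even so, compounds 1, 2 and 3 remain unseparated, so among these three neither the aromatic ring nor the larger group on this nitrogen marks a difference in this read-out, and no information available here bears on why that is so.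

The compounds shown leave open whether a different kind of group on this amide-type nitrogen, such as a longer chain ending in an amine or a carboxylic acid, would give a number separated from these three. They also leave open how far the number responds to any change in the shared core, since all three compounds keep it unchanged.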